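Methyl on the ring nitrogen: compound 2 to compound 3

A few compounds are considered here, and "the series" means these few. Any claim that something is new, unique, unknown or untested is made for them only; others in the source may bear on it.

Two members of the series carry numbers in a functional assay on MIA PaCa-2 cells (Homo sapiens) for cytotoxicity; a higher number here means a weaker inhibitor, a lower number a stronger inhibitor. Compound 1 `COc1ccc(Cn2cc(/C=N\NC(=O)c3c[nH]c4ccc(Br)cc34)c3ccc(F)cc32)cc1` gives 45500 nM. Compound 2 `COc1ccc(Cn2cc(/C=N\NC(=O)c3c[nH]c4ccccc34)c3ccc(F)cc32)cc1` gives 43300 nM. Going by the values given here, the single step between them, a 1.1-fold lower number from compound 1 to compound 2 (0.02 log units; within the scatter), replaces a bromo on an aromatic carbon with hydrogen and leaves the number essentially where it was. Among the compounds with values here, compound 2 thus holds the lowest of the two numbers, yet its only neighbour, compound 1, sits within the scatter, so no order between the two can be read.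

Compound 3 `COc1ccc(Cn2cc(/C=N\NC(=O)c3cn(C)c4ccccc34)c3ccc(F)cc32)cc1` is not yet measured. Its difference from compound 2 is methyl in place of hydrogen on an aromatic nitrogen; cut one bond further out, the change reads 1H-indol-3-yl to 1-methyl-1H-indol-3-yl. No measured step touches this nitrogen; the only step shown, a 1.1-fold lower number from compound 1 to compound 2 (0.02 log units; within the scatter), concerns an aromatic carbon elsewhere and stayed within the scatter. The shown numbers therefore give no ground for a shift in either direction in this assay, and the expected step for compound 3 is a 1.0-fold lower number from compound 2 to compound 3 (0.00 log units; within the scatter), none beyond the scatter. Compound 3 is estimated at 43000 nM, with a range from 18000 nM to 100000 nM.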

Compound 3, half-maximal inhibitory concentration: 55800 nM
Compound 3: the middle estimate sits 1.3-fold (0.11 log units) below what was measured; the range from low to high includes it.
By their numbers in this assay, from the lowest: compounds 2, 1 and 3 (each within the scatter of the next).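

In this assay, the aromatic nitrogen of the five-membered ring now has a measured change of its own: methyl in place of hydrogen gives a 1.3-fold higher number from compound 2 to compound 3 (0.11 log units; within the scatter) and does not move the number beyond the scatter, so the hydrogen on this nitrogen is not shown to matter for this read-out. The comparison with the bromo compound, 1-methyl-1H-indol-3-yl in place of 5-bromo-1H-indol-3-yl, gives a 1.2-fold higher number from compound 1 to compound 3 (0.09 log units; within the scatter) and is also within the scatter, so compounds 1, 2 and 3 fall within the scatter of one another and can be put in no order, with neither the methyl nor the bromo change separating from the parent group. Nothing at hand bears on why these changes leave the number in place.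

Still open, from the compounds shown here alone, is whether anything larger than methyl on this nitrogen, such as a longer chain ending in an amine or a carboxylic acid, would shift the number beyond the scatter. Also open is whether a change elsewhere on the shared core would do so, as the compounds shown vary only on the 1H-indol-3-yl group.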